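The source may hold more compounds than are shown below. What is called first, only, known or untested is meant among the compounds shown, and "the series" means these compounds.

Within the data shown here, in a functional assay on RAW264.7 cells (Mus musculus) for inhibition, read by MTT assay (a higher number here means a weaker inhibitor, a lower number a stronger inhibitor), compound 1 (`Oc1ccc(/C=C/CC[C@@H](O)CCc2ccc(O)c(O)c2)cc1`) gives 20600 nM, the higher of the two numbers measured so far, while compound 2 (`Oc1ccc(CC[C@H](O)CC/C=C/c2ccccc2)cc1O`) gives 7340 nM. Compound 3 (`CC(=O)O[C@H](CC/C=C/c1ccc(O)cc1)CCc1ccc(O)c(O)c1`) is still unmeasured and differs from compound 1 by acetyl in place of hydrogen on an oxygen on a saturated carbon. Among the measured compounds shown here, the only measured step, a 2.8-fold lower number from compound 1 to compound 2 (0.45 log units; beyond the scatter), is modest and lies at another place, so it bears on this change only loosely. A similarly modest move toward a lower number is tentatively expected, namely a 1.7-fold lower number from compound 1 to compound 3 (0.23 log units; within the scatter). For compound 3 the estimated value is 12000 nM, with an expected range of 4000 nM to 32000 nM.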

Compound 3, half-maximal inhibitory concentration: 15600 nM
Compound 3: the middle estimate sits 1.3-fold (0.11 log units) below what was measured; the range from low to high includes it.
By their numbers in this assay, from the lowest: compound 2; then compounds 3 and 1 (each within the scatter of the next).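

Among these compounds, this is the first look at the oxygen on the saturated carbon, and hydroxy to acetoxy there gives, in this assay, a 1.3-fold lower number from compound 1 to compound 3 (0.12 log units; within the scatter). The two numbers thus stay within the scatter of each other, so at this position, acetyl can stand in place of the hydrogen with no readable shift in this assay. No measurement offers an explanation for this result. The compounds shown leave open whether a benzoyl group or a methyl ether on this oxygen, or an amine in place of the hydroxy, would read the same. They also leave open whether acetyl would behave alike on compound 2.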